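A few compounds are considered here, and "the series" means these few. Any claim that something is new, unique, unknown or untested is made for them only; others in the source may bear on it.

Measured in a functional assay on ECa-109 cells (Homo sapiens) for cytotoxicity, read by MTT assay, with a stated time of 72 h; on this read-out lower numbers stand for stronger inhibition and higher numbers for weaker inhibition:
- compound 1 `COc1ccc(C=C2C(=O)N(c3ccc(Cl)cc3)N(c3ccc(Cl)cc3)C2=O)cc1`: > 128000 nM, a limit of the assay and not a number
- compound 2 `COc1cccc(C=C2C(=O)N(c3ccc(Cl)cc3)N(c3ccc(Cl)cc3)C2=O)c1`: 29000 nM

For the measured compounds named here, compound 2, at 29000 nM, holds the only true number in this assay. The one other result, that of compound 1, is a limit. The next compound, compound 3 `COc1cccc(C=C2C(=O)N(c3ccc(Cl)cc3)N(c3ccc(Cl)cc3)C2=O)c1OC`, differs from compound 2 in one place: methoxy in place of hydrogen on an aromatic carbon. This puts methoxy in place of hydrogen on an aromatic carbon, turning 3-methoxyphenyl into 2,3-dimethoxyphenyl, with the new group ortho to a large group and ortho to a methoxy group.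

Going by the values given here, only one measured step bears on this change, an at least 4.4-fold lower number from compound 1 to compound 2 (0.64 log units; beyond the scatter). It shows that the read-out responds to where a methoxy group sits on this ring. Its size is only a bound, set by the limit of > 128000 nM in this assay, at which 1 of the 2 values shown sits. Among the compounds with values here, no measured step adds a second methoxy group, so the direction remains open, and a large shift cannot be argued from these data.

The expected step is a 1.1-fold higher number from compound 2 to compound 3 (0.04 log units; within the scatter), which would not go beyond the scatter. For compound 3 the estimated value is 32000 nM, with an expected range of 11000 nM to 95000 nM.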

Compound 3, half-maximal inhibitory concentration: 6800 nM
Beside the measured number, compound 3's estimate is 4.7-fold (0.67 log units) above it; the whole stated range lies above it.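

Adding methoxy on this aromatic carbon, ortho to a large group and ortho to a methoxy group, gives the first measured step in this assay that adds a second methoxy group instead of moving one, and it settles the direction left open by the earlier compounds: the change from 3-methoxyphenyl to 2,3-dimethoxyphenyl gives a 4.3-fold lower number from compound 2 to compound 3 (0.63 log units; beyond the scatter). Set against the 4-methoxyphenyl compound, the 2,3-dimethoxyphenyl ring gives an at least 18-fold lower number from compound 1 to compound 3 (1.27 log units; beyond the scatter), so the read-out again responds to how the ring is substituted, though the size of this step is only a bound. The result of compound 1 is a limit of the assay and not a number: the limit of > 128000 nM in this assay, at which 1 of the 3 values shown sits.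

The compounds shown carry only methoxy on this ring, so it stays open whether the step belongs to methoxy itself or would also come with a hydroxy group, an ethoxy group or a fluorine atom on the same carbon. On these data alone, it also stays open whether a second methoxy group placed elsewhere on the ring would give a step of the same size.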